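This account rests on a few compounds, and the source may have more. Where it says the series, first, only, none or still open, it means among the compounds named here.

Measured compounds in a functional assay on Rec1 cells (Homo sapiens) for inhibition, read by luminescence and CellTiter-Glo, with a stated time of 72 h; a higher number here means a weaker inhibitor, a lower number a stronger inhibitor:
- compound 1, `O=C(CCl)Nc1ccc(Cn2nc(-c3ccc(Oc4ccccc4)cc3)cc2CO)cc1`; compound 1 gives 400 nM
- compound 2, `C=CC(=O)N1CCCC(n2nc(-c3ccc(Oc4ccccc4)cc3)cc2C(=O)OCC)C1`; compound 2 gives 13800 nM
- compound 3, `C=CC(=O)Nc1ccc(Cn2nc(-c3ccc(Oc4ccccc4)cc3)cc2CO)cc1`; compound 3 gives 3500 nM

Compound 2 sits highest of the three numbers; its nearest neighbour is compound 3, and compound 1 lies furthest from it. The difference between the core of compound 2 and the core of compound 3 is not broken down here.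

Within the core of compound 3, the change chloromethyl in place of vinyl on a carbonyl carbon gives an 8.8-fold lower number from compound 3 to compound 1 (0.94 log units; beyond the scatter) in this assay.

Compound 4, `CCOC(=O)c1cc(-c2ccc(Oc3ccccc3)cc2)nn1C1CCCN(C(=O)CCl)C1`, is not yet measured. It differs from compound 2 by chloromethyl in place of vinyl on a carbonyl carbon. This is the same kind of change as from compound 3 to compound 1, but not the same: in compound 1 the carbonyl carbon's other neighbour is an amide-type nitrogen, while in compound 4 it is an amide-type nitrogen in a ring.

Because compound 3 to compound 1 showed an 8.8-fold lower number from compound 3 to compound 1 (0.94 log units; beyond the scatter), a step in the same direction is expected from compound 2 to compound 4, though tempered for the different core. The step expected for compound 4 is a 4.6-fold lower number from compound 2 to compound 4 (0.66 log units; beyond the scatter). Compound 4 is thus estimated at 3000 nM, with a range from 800 nM to 10000 nM.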

Compound 4, half-maximal inhibitory concentration: 400 nM
Compound 4: middle estimate off by 7.5-fold (0.88 log units), on the high side, and the stated range ends above it.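

In this assay, chloromethyl in place of vinyl on a carbonyl carbon gives a 35-fold lower number from compound 2 to compound 4 (1.54 log units; beyond the scatter), a large step on the core of compound 2. On the two cores shown, the direction of the change carries over, but its size does not: the same change on two cores in this assay, an 8.8-fold lower number (0.94 log units; beyond the scatter) from compound 3 to compound 1 and a 35-fold lower number (1.54 log units; beyond the scatter) from compound 2 to compound 4, 3.9-fold (0.60 log units) apart, beyond the scatter of two such steps

These two pairs do not show which part of the core sets the size of the step, and they give no size to expect on a third core, so the change can be carried across this series for its direction only.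

The compounds shown leave open whether the larger step goes with the amide-type nitrogen in a ring or with the ethyl ester, as these two features always appear together on the same core and are never seen apart. Also open, from the compounds shown here alone, is how a different group on the carbonyl carbon, such as bromomethyl or a longer chain, would compare with chloromethyl and vinyl on either core.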